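A few compounds are considered here, and "the series" means these few. Any claim that something is new, unique, unknown or untested is made for them only; others in the source may bear on it.

Measured compounds:
- Compound 1, `COc1cc2c(Oc3ccc(NC(=O)c4cc(-c5ccccc5)ccn4)cc3F)ccnc2cc1OCCCN1CCN(C)CC1`: 91 nM
- Compound 2, `COc1cc2c(Oc3ccc(NC(=O)c4cc(-c5ccc(C(F)(F)F)cc5)ccn4)cc3F)ccnc2cc1OCCCN1CCCCC1`: 360 nM
- Compound 3, `COc1cc2c(Oc3ccc(NC(=O)c4cc(-c5ccccc5)ccn4)cc3F)ccnc2cc1OCCCN1CCCC1`: 130 nM

All three were tested in a functional assay on NCI-H460 cells (Homo sapiens) for cytotoxicity, read by MTT assay, with a stated time of 72 h; a higher number here means a weaker inhibitor, a lower number a stronger inhibitor. Among them compound 3 stands second highest of the three numbers; its nearest neighbour is compound 1, and the step of a 1.4-fold higher number from compound 1 to compound 3 (0.15 log units; within the scatter) lies within the scatter, so the two cannot be told apart. Compound 2 gives the highest number of the set, beyond the scatter from compound 3, but compound 2 differs from compound 3 in two places at once, so no single step can be read from that pair.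

Compound 4, `COc1cc2c(Oc3ccc(NC(=O)c4cc(-c5ccccc5C)ccn4)cc3F)ccnc2cc1OCCCN1CCCC1`, is the next compound. The change from compound 3 is methyl in place of hydrogen on an aromatic carbon, that is, phenyl becomes 2-methylphenyl. Going by the values given here, no measured step touches this phenyl ring; the only measured step concerns the amine on the chain. The expectation therefore rests on little, and the estimated step of a 1.5-fold higher number from compound 3 to compound 4 (0.19 log units; within the scatter) is taken as small, with a slight lean towards a higher number. Compound 4 is expected to give about 200 nM, between 70 nM and 600 nM.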

Compound 4, half-maximal inhibitory concentration: 420 nM
The estimate for compound 4 lay 2.1-fold (0.32 log units) below the measured number; measured number inside the range.
By their numbers in this assay, from the lowest: compounds 1 and 3 (each within the scatter of the next); then compounds 2 and 4 (each within the scatter of the next).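

In this assay, going by these compounds alone, a single added methyl that turns phenyl into 2-methylphenyl gives a 3.2-fold higher number from compound 3 to compound 4 (0.51 log units; beyond the scatter) and so lies beyond the scatter, while the one earlier step, at the amine on the chain, gives a 1.4-fold higher number from compound 1 to compound 3 (0.15 log units; within the scatter) and stays within it. Within the data shown here, this phenyl ring is therefore a place where one extra heavy atom is enough to shift the number, something no earlier single-place step could show, since none of them touched this ring. Nothing measured here explains the rise.

As far as these compounds go, whether a fluorine or a methoxy group in place of this methyl would shift the number as far remains open. So does whether the same methyl would give a similar step with 4-methylpiperazin-1-yl on the chain in place of pyrrolidin-1-yl.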